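The compounds below may be only part of what the source reports. "The series", "measured", "known", "first", "only" and "open" are said of these compounds alone.

Measured compounds in this series:

- compound 1, `COc1cc(/C=C/C(=O)OCCSc2nc(-c3ccc(S(C)(=O)=O)cc3)n(-c3ccc(Br)cc3)n2)ccc1OC(C)=O`: 12400 nM
- compound 2, `COc1cc(/C=C/C(=O)OCCSc2nc(-c3ccc(S(C)(=O)=O)cc3)n(-c3ccc(C(F)(F)F)cc3)n2)ccc1OC(C)=O`: 10500 nM

Within the data shown here, in a functional assay on B16-F10 cells (Mus musculus) for antiproliferative activity, read by MTT assay, with a stated time of 72 h (a higher number here means a weaker inhibitor, a lower number a stronger inhibitor), compound 2 carries the lowest of the two numbers, but its only neighbour is compound 1, and the one measured step, a 1.2-fold lower number from compound 1 to compound 2 (0.07 log units; within the scatter), lies within the scatter, so the two compounds cannot be ordered. That step concerns only the aryl substituent on the core and says nothing about the ester end of the molecule.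

Compound 3, `COc1cc(/C=C/C(=O)OCCSc2nc(-c3ccc(S(C)(=O)=O)cc3)n(-c3ccc(C(F)(F)F)cc3)n2)ccc1O`, differs from compound 2 by hydrogen in place of acetyl on an oxygen on an aromatic ring. Among the measured compounds shown here, no measured step in this assay touches the acetoxy group; both measured compounds carry it unchanged. With nothing to indicate a direction, the expectation for compound 3 is a step no larger than the scatter, no change at the digits printed from compound 2 to compound 3 (within the scatter). The estimate for compound 3 in this assay is therefore 10500 nM, with a range from 4000 nM to 28000 nM.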

Compound 3, half-maximal inhibitory concentration: 8650 nM
Estimate against measurement, compound 3: 1.2-fold (0.08 log units) above; measured number inside the range.
By their numbers in this assay, from the lowest: compounds 3, 2 and 1 (each within the scatter of the next).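

In this assay, hydrogen in place of acetyl on the oxygen of the aromatic ring gives a 1.2-fold lower number from compound 2 to compound 3 (0.08 log units; within the scatter), so acetoxy to hydroxy cannot be told from no change, and compound 2 and compound 3 cannot be ordered. Among these compounds, this is the first measured step at this end of the molecule, and it shows that, with trifluoromethyl on the aryl substituent, 4-acetoxy-3-methoxyphenyl and 4-hydroxy-3-methoxyphenyl give values within the scatter of each other. No further data bear on this result.

As far as these compounds go, it remains open whether a butyryl ester or a carbamate on that oxygen, or a carboxylic acid in place of the cinnamate ester, would move the number beyond the scatter. Also open, from the compounds shown here alone, is whether the same step reads alike with the bromo substituent of compound 1.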